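The compounds below may be only part of what the source reports. "The series", "measured", "known", "first", "only" and "open" are said of these compounds alone.

Of the compounds shown here, three sharing one core have been measured in a functional assay on HCT-116 cells (Homo sapiens) for antiproliferative activity, read by MTT assay, with a stated time of 48 h; on this read-out lower numbers stand for stronger inhibition and higher numbers for weaker inhibition. Compound 1 `O=C(/C=C/c1cccc(NC(=O)c2ccccc2Br)c1)c1nc2ccccc2[nH]1` gives 1680 nM; compound 2 `Cc1ccccc1C(=O)Nc1cccc(/C=C/C(=O)c2nc3ccccc3[nH]2)c1` gives 1870 nM; compound 3 `O=C(Nc1cccc(/C=C/C(=O)c2nc3ccccc3[nH]2)c1)c1cc(Cl)cc(Cl)c1` gives 1650 nM. Compound 1 stands second highest of the three numbers, with compound 3 nearest and compound 2 furthest, and both gaps lie within the scatter. The steps among them were a 1.1-fold higher number from compound 1 to compound 2 (0.05 log units; within the scatter), a 1.0-fold lower number from compound 1 to compound 3 (0.01 log units; within the scatter) and a 1.1-fold lower number from compound 2 to compound 3 (0.05 log units; within the scatter), each within the scatter, so the three aryl groups on the carbonyl carbon cannot be told apart on this read-out.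

Compound 4 `Cc1cccc(S(=O)(=O)Nc2cccc(/C=C/C(=O)c3nc4ccccc4[nH]3)c2)c1` has not yet been measured. It differs from compound 1 in one place: (3-methylphenyl)sulfonyl in place of (2-bromophenyl)carbonyl on a nitrogen on an aromatic ring. For the measured compounds named here, none of the measured steps bears directly on this change; each exchanged one aryl group for another on a carbonyl carbon, whereas here the carbonyl itself gives way to a sulfonyl. What the measured steps do show is that bromo, methyl and dichloro variation of the aryl portion of this group gave no step beyond the scatter. From the compounds shown here alone, on that slim basis the step from compound 1 to compound 4 is expected to be small, a 1.1-fold higher number from compound 1 to compound 4 (0.03 log units; within the scatter), but the exchange of the carbonyl for a sulfonyl is untested, so the uncertainty is wide. Compound 4 is therefore estimated at 1800 nM in this assay, within a range from 600 nM to 5500 nM.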

Compound 4, half-maximal inhibitory concentration: 597 nM
The estimate for compound 4 lay 3.0-fold (0.48 log units) above the measured number; the measured number lies below the stated range.
By their numbers in this assay, from the lowest: compound 4; then compounds 3, 1 and 2 (each within the scatter of the next).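

In this assay, exchanging one aryl group for another on the carbonyl carbon had moved the number by no more than the scatter, but replacing the whole group on the nitrogen on an aromatic ring gives a 2.8-fold lower number from compound 1 to compound 4 (0.45 log units; beyond the scatter), a 2.8-fold lower number from compound 3 to compound 4 (0.44 log units; beyond the scatter) and a 3.1-fold lower number from compound 2 to compound 4 (0.50 log units; beyond the scatter). This position therefore does respond on this read-out, and compound 4, whose steps to all three others lie beyond the scatter, is the strongest of the four compounds. The change brings in the sulfonyl and the 3-methylphenyl ring together, so these compounds cannot assign the step to either part alone, and nothing measured here gives a reason for it.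

From the compounds shown here alone, what remains open is whether (3-methylphenyl)carbonyl on this nitrogen would stay with compounds 1, 2 and 3 or move towards compound 4, and whether (2-bromophenyl)sulfonyl would keep the lower number. Also open, going by these compounds, is whether the aromatic ring on the sulfonyl is needed at all, which a methylsulfonyl group on the same nitrogen would test.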